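Methyl in place of hydrogen on the benzyl ring

A few compounds are considered here, and "the series" means these few. Any claim that something is new, unique, unknown or untested is made for them only; others in the source may bear on it.

Measured compounds:
- compound 1 `c1ccc(CO/N=C2/C(c3c[nH]c4ccccc34)=Nc3ccccc32)cc1`: 19300 nM
- compound 2 `Fc1ccc2c(c1)/C(=N\OCc1ccccc1)C(c1c[nH]c3ccc(F)cc13)=N2`: 10500 nM

Both numbers come from a functional assay on A549 cells (Homo sapiens) for cytotoxicity, read by MTT assay, with a stated time of 2 days; on this read-out lower numbers stand for stronger inhibition and higher numbers for weaker inhibition. In this assay compound 1 gives 19300 nM, and compound 2 gives 10500 nM. Compound 1 holds the higher of the two numbers, but the gap to compound 2 lies within the usual scatter of repeated measurements, so the two cannot be ranked against each other, and neither can be called the more or less active one.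

Compound 3 `Cc1ccc(CO/N=C2/C(c3c[nH]c4ccccc34)=Nc3ccccc32)cc1` has not been measured. It differs from compound 1 in one place: methyl in place of hydrogen on an aromatic carbon, which is methyl in place of hydrogen on an aromatic carbon, para to a large group. Among the measured compounds shown here, no pair of measured compounds differs by this change alone, so the data give no step that shows what it does in this assay. With nothing pointing either way, the step from compound 1 to compound 3 is expected to stay within the scatter, which is what the estimate a 1.2-fold lower number from compound 1 to compound 3 (0.08 log units; within the scatter) means. Compound 3 is therefore expected to give about 16000 nM, with a range from 5000 nM to 50000 nM, and the measurement will show whether that holds.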

Compound 3, half-maximal inhibitory concentration: 22400 nM
The estimate for compound 3 lay 1.4-fold (0.15 log units) below the measured number; low and high end bracket the measured number.
By their numbers in this assay, from the lowest: compounds 2, 1 and 3 (each within the scatter of the next, the first and the last beyond it).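

In this assay, going from benzyl to 4-methylbenzyl gives a 1.2-fold higher number from compound 1 to compound 3 (0.06 log units; within the scatter), so at this place on the ring, para to a large group, the added methyl produces no difference that can be told apart from repeat-to-repeat variation. Among the compounds shown here, this is the first reading of a change made in one place alone, since compound 1 and compound 2 differ in more than one place and offered no such step; it shows that this one change, on this one background, leaves the number within the scatter. Nothing available here gives any explanation for this result.

Going by these compounds, a single methyl says little about the position as a whole, and it remains open whether a different group there, such as a methoxy, a chlorine, an amine or a carboxylic acid, would shift the number beyond the scatter. On these data alone, it is also open whether the same methyl would leave the number as little changed on the fluorine-bearing compound 2, or whether its effect depends on the rest of the molecule.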